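Swapping the aryl group on the sulfonyl: nitrile to dichloride

This account rests on a few compounds, and the source may have more. Where it says the series, first, only, none or still open, it means among the compounds named here.

Three compounds sharing one core differ only in the aromatic group attached to the sulfonyl sulfur. In a functional assay on DLD-1 cells (Homo sapiens) for antiproliferative activity, read by CellTiter-Glo, with a stated time of 72 h (on this read-out higher numbers stand for weaker inhibition and lower numbers for stronger inhibition), compound 2 `Cc1ccc(S(=O)(=O)N2CCC(N3CCC(C)CC3)CC2)cc1C` gives 24 nM. Compound 3 `CC1CCN(C2CCN(S(=O)(=O)c3ccc(C#N)cc3)CC2)CC1` gives 2800 nM in this assay. Compound 1 `CC1CCN(C2CCN(S(=O)(=O)c3cccnc3Cl)CC2)CC1` returns only a limit in this assay, > 5000 nM, so it yields no number. Among the two numbers available, compound 3 stands highest, meaning it inhibits most weakly; the step of a 120-fold higher number from compound 2 to compound 3 (2.07 log units; beyond the scatter) is large, while an at least 1.7-fold lower number from compound 1 to compound 3 (0.25 log units; that floor lies within the scatter) cannot be judged because the starting point is a limit (the limit of > 5000 nM in this assay, at which 1 of the 3 values shown sits).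

Compound 4 `CC1CCN(C2CCN(S(=O)(=O)c3ccc(Cl)c(Cl)c3)CC2)CC1` is the next variation, carrying the change (3,4-dichlorophenyl in place of 4-cyanophenyl on a sulfonyl sulfur). Going by the values given here, the entering group resembles the 3,4-dimethylphenyl of compound 2 in having two substituents on the ring, rather than the single nitrile of compound 3. The most relevant measured step is a 120-fold higher number from compound 2 to compound 3 (2.07 log units; beyond the scatter), together with an at least 200-fold lower number from compound 1 to compound 2 (2.31 log units; beyond the scatter), both showing that the 3,4-dimethylphenyl group sits far stronger than either alternative. The expectation is therefore a large step in the opposite direction, estimated as a 70-fold lower number from compound 3 to compound 4 (1.85 log units; beyond the scatter). For compound 4 the expected result in this assay is 40 nM, likely within 10 nM to 250 nM.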

Compound 4, half-maximal inhibitory concentration: 2.9 nM
Estimate against measurement, compound 4: 14-fold (1.14 log units) above; the measured number lies below the stated range.
By their numbers in this assay, from the lowest: compound 4; then compound 2; then compound 3. At a limit, above all of these: compound 1.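

Going by these compounds alone, the 3,4-dichlorophenyl group on the sulfonyl sulfur gives the lowest number so far in this assay, and it goes further than the 3,4-dimethylphenyl group that had led until now (an 8.3-fold lower number from compound 2 to compound 4 (0.92 log units; beyond the scatter)). Against the 4-cyanophenyl group the change is far larger (a 970-fold lower number from compound 3 to compound 4 (2.98 log units; beyond the scatter)), even though the leaving and entering groups hold the same number of heavy atoms, so in this pair the heavy-atom count of the group does not decide the result. The widest gap in the set (an at least 1700-fold lower number from compound 1 to compound 4 (3.23 log units; beyond the scatter)) starts from a limit rather than a number, so it gives only a floor for the true size of the step: the limit of > 5000 nM in this assay, at which 1 of the 4 values shown sits.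

Open, on these data alone, is whether both chlorines are needed, since a 4-chlorophenyl or a 3-chlorophenyl group would show what each one contributes on its own. Also open, as far as these compounds go, is how far this trend extends to other groups on the ring, such as a 3,4-difluorophenyl or a 3,4-dimethoxyphenyl, and whether the gain survives when the rest of the shared core is changed.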